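A few compounds are considered here, and "the series" means these few. Any claim that something is new, unique, unknown or untested is made for them only; others in the source may bear on it.

In a functional assay on A549 cells (Homo sapiens) for inhibition, read by sulforhodamine B assay, with a stated time of 72 h (on this read-out lower numbers stand for stronger inhibition and higher numbers for weaker inhibition), compound 1 (`COc1cc2c(Nc3ccc(F)c(Cl)c3)ncnc2cc1OCCCCCCn1ccnc1[N+](=O)[O-]`) gives 6520 nM as its value. Compound 2 (`COc1cc2c(Nc3ccc(F)c(Cl)c3)ncnc2cc1OCCOCCn1ccnc1[N+](=O)[O-]`) gives 7640 nM on the same read-out, so the two stand level within the usual scatter. Compound 3 (`COc1cc2c(Nc3cccc(Br)c3)ncnc2cc1OCCCCCCn1ccnc1[N+](=O)[O-]`) keeps the chain of compound 1 and alters only the aromatic group on the nitrogen (3-bromophenyl in place of 3-chloro-4-fluorophenyl on a nitrogen on an aromatic ring), with 3-bromophenyl in place of 3-chloro-4-fluorophenyl. Among the measured compounds shown here, the only measured step (a 1.2-fold higher number from compound 1 to compound 2 (0.07 log units; within the scatter)) lies in the chain, not in this group, so it offers no direct guide to this change. For the measured compounds named here, with no measured step on this group, no shift beyond the scatter is expected in this assay for compound 3, though this expectation is loose. The step expected for compound 3 is small (a 1.0-fold lower number from compound 1 to compound 3 (0.00 log units; within the scatter)). For compound 3 the estimated value is 6500 nM with an expected range from 3000 nM to 14000 nM on repeated measurement.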

Compound 3, half-maximal inhibitory concentration: 20200 nM
Estimate against measurement, compound 3: 3.1-fold (0.49 log units) below; the measured number lies above the stated range.
By their numbers in this assay, from the lowest: compounds 1 and 2 (each within the scatter of the next); then compound 3.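

In this assay, the group on the nitrogen responds where the chain did not: 3-bromophenyl in place of 3-chloro-4-fluorophenyl gives a 3.1-fold higher number from compound 1 to compound 3 (0.49 log units; beyond the scatter), whereas the chain change gave only a 1.2-fold higher number from compound 1 to compound 2 (0.07 log units; within the scatter). With the chain and the core held fixed, this modest step shows that inhibition in these cells depends on the aromatic group at this position, and that the 3-bromophenyl version is the weaker of this pair. No measurement at hand says why the number rises.

The compounds shown do not tell whether the step comes from losing the fluorine, losing the chlorine or gaining the bromine; a 3-chlorophenyl or 4-fluorophenyl group on the same nitrogen would help to separate these. As far as these compounds go, whether the same step appears with the chain of compound 2 also stays open.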